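This account rests on a few compounds, and the source may have more. Where it says the series, first, only, none or still open, it means among the compounds named here.

Values in a functional assay on OVCAR-3 cells (Homo sapiens) for inhibition, read by MTT assay, with a stated time of 24 h; a lower number here means a stronger inhibitor, a higher number a weaker inhibitor:
compound 1 `CC1(C)[C@H]2CC[C@]1(C)N(Cc1cn(-c3cccc(F)c3)nn1)C(=O)C2`: 430 nM
compound 2 `CC1(C)[C@H]2CC[C@]1(C)N(Cc1cn(-c3ccccc3F)nn1)C(=O)C2`: 300 nM
compound 3 `CC1(C)[C@H]2CC[C@]1(C)N(Cc1cn(-c3cccc(Cl)c3)nn1)C(=O)C2`: 50 nM

Compound 2 belongs to the upper pair of these three values. The two fluorophenyl compounds are not separated (a 1.4-fold lower number from compound 1 to compound 2 (0.16 log units; within the scatter)), and the one clear gap lies below them (a 6.0-fold lower number from compound 2 to compound 3 (0.78 log units; beyond the scatter)).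

Compound 4 `COc1ccccc1-n1cc(CN2C(=O)C[C@@H]3CC[C@@]2(C)C3(C)C)nn1` has not yet been measured. It differs from compound 2 by methoxy in place of fluoro on an aromatic carbon, with methoxy in place of fluoro on an aromatic carbon, ortho to a large group. The same difference reads 2-fluorophenyl to 2-methoxyphenyl.

Within the data shown here, no measured step has methoxy entering, so the evidence is indirect. The closest case of another group replacing fluoro has chloro entering on the 3-fluorophenyl group (an 8.6-fold lower number from compound 1 to compound 3 (0.93 log units; beyond the scatter)), a modest step toward a lower number. It involves a different group on a different aryl substituent, so it supports only a weak lean in that direction. A small move toward a lower number in this assay is therefore expected, not beyond the scatter, with wide uncertainty on either side. The expected change is a 1.5-fold lower number from compound 2 to compound 4 (0.18 log units; within the scatter). For compound 4 the estimated value is 200 nM, with an expected range of 55 nM to 700 nM.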

Compound 4, half-maximal inhibitory concentration: 140 nM
The estimate for compound 4 lay 1.4-fold (0.15 log units) above the measured number; the range from low to high includes it.
By their numbers in this assay, from the lowest: compound 3; then compound 4; then compounds 2 and 1 (each within the scatter of the next).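

In this assay, the change from 2-fluorophenyl to 2-methoxyphenyl shows that this place, ortho to a large group, responds to the group it carries: a 2.1-fold lower number from compound 2 to compound 4 (0.33 log units; beyond the scatter), a step just beyond the scatter, whereas moving fluoro alone had not separated the earlier pair (a 1.4-fold lower number from compound 1 to compound 2 (0.16 log units; within the scatter)). Compound 4 also stands clear of the other fluorophenyl compound (a 3.1-fold lower number from compound 1 to compound 4 (0.49 log units; beyond the scatter)) but does not reach the 3-chlorophenyl compound (a 2.8-fold higher number from compound 3 to compound 4 (0.45 log units; beyond the scatter)), so methoxy at this place gives a real but partial gain and leaves the 3-chlorophenyl group ahead among the compounds shown. No measurement shown bears on what lies behind these steps.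

Open, from the compounds shown here alone, is whether the lower number belongs to methoxy specifically or would also appear with ethoxy or an amine at the same place. Also open, going by these compounds, is how far the lower number of compound 3 depends on chloro itself and how far on where it sits, as chloro and methoxy appear here only on differently substituted phenyl groups.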